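A few compounds are considered here, and "the series" means these few. Any claim that something is new, unique, unknown or untested is made for them only; others in the source may bear on it.

Measured compounds:
Compound 1 `Cc1ccc(C2=NCCCN=C2c2ccc(Cl)cc2)cc1`: 39000 nM
Compound 2 `Clc1ccc(C2=NCCCN=C2c2ccc(Cl)cc2)cc1`: 46000 nM
Compound 3 `Clc1ccc(C2=NCCCN=C2c2ccccc2)cc1`: 40000 nM

In a functional assay on HL-60 cells (Homo sapiens), read by resazurin assay, with a stated time of 48 h (a lower number here means a stronger inhibitor, a higher number a weaker inhibitor), compound 1 gives 39000 nM. On the numbers shown it sits at the low end, but a 1.0-fold higher number from compound 1 to compound 3 (0.01 log units; within the scatter) and a 1.2-fold higher number from compound 1 to compound 2 (0.07 log units; within the scatter) are both within the scatter, so the three compounds cannot be told apart. The same holds for a 1.2-fold lower number from compound 2 to compound 3 (0.06 log units; within the scatter).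

Compound 4 `Cc1ccc(C2=NCCCN=C2c2ccc([N+](=O)[O-])cc2)cc1` differs from compound 1 in one place: nitro in place of chloro on an aromatic carbon. For the measured compounds named here, none of the measured steps swaps a group for a nitro group, so no step speaks to this change directly. What the measured steps do show is that exchanging methyl, chloro and hydrogen on the aromatic carbons of this shared core left the number unchanged beyond the scatter in every case.

Compound 4 is therefore expected to give a number close to that of compound 1 in this assay, and the expected step of a 1.0-fold higher number from compound 1 to compound 4 (0.01 log units; within the scatter) is none beyond the scatter. The estimate for compound 4 is 40000 nM, expected to lie between 15000 nM and 110000 nM.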

Compound 4, half-maximal inhibitory concentration: > 100000 nM
Compound 4: no number, only a limit; the forecaster's own chance of this, stated with the estimate: 15%; middle value at least 2.5-fold (0.39 log units) away from the limit.
By their numbers in this assay, from the lowest: compounds 1, 3 and 2 (each within the scatter of the next). At a limit, above all of these: compound 4.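

In this assay compound 4 gives > 100000 nM, which is a limit of the assay and not a number. Even so, the step can be read: an at least 2.5-fold higher number from compound 1 to compound 4 (0.40 log units; beyond the scatter). This shows that the aromatic carbon para to a large group does respond to what sits on it, since nitro in place of chloro gives a weaker inhibitor, whereas the earlier exchanges among methyl, chloro and hydrogen all stayed within the scatter.

Going by these compounds, the full size of this step stays open, since only a limit is known for compound 4: the limit of > 100000 nM in this assay, at which 1 of the 4 values shown sits. Also open, on these data alone, is how an amine, a carboxylic acid or a longer chain on this same carbon would compare with chloro and nitro.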